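Benzyloxy to ((1-bromoethenyl)carbonyl)amino on the shared core

The source may report more compounds than this note shows. Statements on the series, on what has been measured and on what is new or still open speak of the compounds shown alone.

Among the measured compounds shown here, in a functional assay on LoVo cells (Homo sapiens) for inhibition, read by MTT assay, with a stated time of 72 h (a lower number here means a stronger inhibitor, a higher number a weaker inhibitor), compound 1 (`COc1cc(NC(=O)/C=C/c2cccc(OCc3ccccc3)c2)cc(OC)c1OC`) gives 21700 nM, the higher of the two numbers so far, and its gap to the other number lies beyond the scatter. That other number belongs to compound 2 (`C=C(Br)C(=O)Nc1cccc(/C=C/C(=O)Nc2ccc(C)cc2)c1`), which gives 1500 nM. Compound 3 (`C=C(Br)C(=O)Nc1cccc(/C=C/C(=O)Nc2cc(OC)c(OC)c(OC)c2)c1`) keeps the core of compound 1 but has ((1-bromoethenyl)carbonyl)amino in place of benzyloxy on an aromatic carbon, meta to a large group: ((1-bromoethenyl)carbonyl)amino in place of benzyloxy on an aromatic carbon. For the measured compounds named here, no step between measured compounds is available. Going by the values given here, the only guide to the entering group is compound 2, which also carries it and gives 1500 nM. A fall in the number well beyond the scatter is therefore expected, and the expected step is a 24-fold lower number from compound 1 to compound 3 (1.38 log units; beyond the scatter). For compound 3 the estimated value is 900 nM, with an expected range of 200 nM to 4000 nM.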

Compound 3, half-maximal inhibitory concentration: 140 nM
Compound 3: the middle estimate sits 6.4-fold (0.81 log units) above what was measured; the measured number lies below the stated range.
By their numbers in this assay, from the lowest: compound 3; then compound 2; then compound 1.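

In this assay, among the compounds shown here, the single change at this aromatic carbon, meta to a large group, gives a 160-fold lower number from compound 1 to compound 3 (2.19 log units; beyond the scatter) and is the first step that can be read at this position. The shared core therefore does not need benzyloxy or its six-membered aromatic ring of carbon only here for a low number, and ((1-bromoethenyl)carbonyl)amino, which brings one hydrogen-bond donor, is compatible with the highest potency among the compounds shown. No measurement shown explains the size of this step.

The change alters the ring, the bromine, the double bonds and the amide hydrogen at once, so the part responsible for the step remains unresolved. A plain amine, an acetylamino group or a propenoylamino group without bromine at this position would help separate these parts.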